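Compound 4 and a Cytotoxicity Read-Out Still at Its Limit

The source may hold more compounds than are shown below. What is called first, only, known or untested is meant among the compounds shown, and "the series" means these compounds.

- compound 1 `COc1cccc([S+]([O-])c2cccc(N)c2C#N)c1` reads > 80000 nM as a limit
- compound 2 `Cc1ccccc1[S+]([O-])c1cccc(N)c1C#N` reads > 200000 nM as a limit
- compound 3 `Cc1ccc([S+]([O-])c2cccc(N)c2C#N)cc1` reads > 200000 nM as a limit

In a functional assay on MT4 cells (Homo sapiens) for cytotoxicity (on this read-out lower numbers stand for stronger inhibition and higher numbers for weaker inhibition), compound 1 stands at > 80000 nM as a limit and not as a number. Its place is the limit of > 80000 nM in this assay, at which 1 of the 3 values shown sits, and none of the three compounds has yet given a number. Compound 4 `N#Cc1c(N)cccc1[S+]([O-])c1cccc(C(F)(F)F)c1` follows from compound 1 by the change trifluoromethyl in place of methoxy on an aromatic carbon with trifluoromethyl in place of methoxy on an aromatic carbon, meta to a large group. For the measured compounds named here, no measured pair shows this change, so in this assay no step beyond the scatter is expected in either direction. The expected step is a step that the limit leaves unreadable from compound 1 to compound 4 as an estimate only. For compound 4 the estimated value is 100000 nM with an expected range from 30000 nM to 250000 nM in this read-out.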

Compound 4, half-maximal inhibitory concentration: 125000 nM
Estimate against measurement, compound 4: 1.3-fold (0.10 log units) below, within the range that was stated.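

The step from compound 1 to compound 4 cannot be read, because compound 1 stands at a limit and not at a number: the limit of > 80000 nM in this assay, at which 1 of the 4 values shown sits.

The compounds shown leave open the size of any step for trifluoromethyl in place of methoxy on an aromatic carbon.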